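From cyclopentylamino to diethylamino: one swap on compound 1

A few compounds are considered here, and "the series" means these few. Any claim that something is new, unique, unknown or untested is made for them only; others in the source may bear on it.

Compound 1 `N=C(NC(=N)NC1CCCC1)Nc1ccc(C(F)(F)F)cc1` gives 3300 nM
Compound 2 `N=C(NC(=N)NC1CCCC1)Nc1ccc(F)cc1F` gives 18400 nM

Both values come from a functional assay on UMUC3 cells (Homo sapiens) for antiproliferative activity, read by MTT assay, with a stated time of 72 h; on this read-out higher numbers stand for weaker inhibition and lower numbers for stronger inhibition. Compound 1 has the lower number of the two, so it is the stronger inhibitor here, and its gap to compound 2 lies beyond the usual scatter of repeated measurements.

The next step starts from compound 1. Compound 3 `CCN(CC)C(=N)NC(=N)Nc1ccc(C(F)(F)F)cc1` keeps the rest of compound 1 but carries diethylamino in place of cyclopentylamino on a carbon with a double bond to nitrogen. For the measured compounds named here, no measured pair shows what this swap does, since compound 1 and compound 2 both carry cyclopentylamino. The expectation in this assay therefore stays anchored on compound 1 (3300 nM) and is only a cautious guess. A modest move towards a higher number, meaning weaker inhibition, is expected (the estimated step: a 2.1-fold higher number from compound 1 to compound 3 (0.33 log units; beyond the scatter)), and it may not clear the scatter. Compound 3 is estimated at 7000 nM (expected range 2500 nM to 20000 nM).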

Compound 3, half-maximal inhibitory concentration: 4900 nM
Estimate against measurement, compound 3: 1.4-fold (0.15 log units) above, within the range that was stated.
By their numbers in this assay, from the lowest: compounds 1 and 3 (each within the scatter of the next); then compound 2.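

In this assay, the swap gives a 1.5-fold higher number from compound 1 to compound 3 (0.17 log units; within the scatter), so the two compounds cannot be told apart at this position on the carbon with a double bond to nitrogen. For the compounds shown here, for this pair, the five-membered carbon ring of cyclopentylamino and the hydrogen-bond donor counted on that group can both leave, with diethylamino entering, without a change that clears the scatter; the earlier compounds both carried cyclopentylamino and could show nothing about this place. Nothing among the data given explains why the two compounds read alike.

The compounds shown leave open whether other groups at this place, such as dimethylamino, a piperidine ring or a longer chain like dibutylamino, would also stay within the scatter of compound 1 or would move clearly away from it. As far as these compounds go, it also remains open whether diethylamino would behave the same way on compound 2, since this one step was read only on the core of compound 1 and cannot be assumed to carry over to a compound that differs elsewhere.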